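Swapping the branched side chain beside the amide

The source may hold more compounds than are shown below. What is called first, only, known or untested is meant among the compounds shown, and "the series" means these compounds.

Compound 1 `CCC(CC)(CCC#N)C(NC(=O)c1ccc(Cl)cc1)N/C(=N/c1cccnc1)NC#N` gives 5010 nM in a functional assay with sulfonylurea receptor 2, Kir6.2 (Homo sapiens) as the target; on this read-out lower numbers stand for an effect already at smaller amounts and higher numbers for an effect only at larger amounts of compound.
Compound 2 `C=CC(C)(C)CC(NC(=O)c1ccc(Cl)cc1)N/C(=N/c1cccnc1)NC#N` gives 10000 nM in this assay.

Only these two numbers are known, and they do not separate: the step of a 2.0-fold higher number from compound 1 to compound 2 (0.30 log units; within the scatter) lies within the scatter, so compound 2 cannot be placed apart from compound 1 on this read-out.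

Compound 3 `CCCCC(C)(C)C(NC(=O)c1ccc(Cl)cc1)N/C(=N/c1cccnc1)NC#N` differs from compound 2 in one place: 1,1-dimethylpentyl in place of 2,2-dimethylbut-3-en-1-yl on a saturated chain carbon bound to an amide-type nitrogen and an amine nitrogen. Among the compounds with values here, the one measured step that touches this position, a 2.0-fold higher number from compound 1 to compound 2 (0.30 log units; within the scatter), exchanged a different pair of groups there and stayed within the scatter. Nothing in the data therefore points to a shift beyond the scatter in either direction, and a step of about a 1.3-fold lower number from compound 2 to compound 3 (0.10 log units; within the scatter) is expected, which amounts to no real change.

For compound 3 the value in this assay is estimated at 8000 nM, with a likely range from 2500 nM to 25000 nM.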

Compound 3, half-maximal effective concentration: < 100000 nM
Compound 3: only a limit was reported; the forecaster's own chance of this, stated with the estimate: 25%; the middle value lies beyond the limit too.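

Compound 3 is reported in this assay with < 100000 nM as a limit and not a number, and its steps from compound 1 and compound 2 cannot be read. The compounds shown leave open whether 1,1-dimethylpentyl changes the number at all, and in which direction.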